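The source may report more compounds than this note shows. Statements on the series, on what has been measured and on what is new or still open speak of the compounds shown alone.

Compound 3 `CCSc1nnc(-c2cc(OC)c(OC)c(OC)c2)n1-c1ccc(N(C)C)cc1` gives 46200 nM in a functional assay on PC-3 cells (Homo sapiens) for inhibition, read by MTT assay, with a stated time of 48 h (on this read-out lower numbers stand for stronger inhibition and higher numbers for weaker inhibition), the lower of the two numbers at hand. Compound 1 `CCSc1nnc(-c2cc(OC)c(OC)c(OC)c2)n1-c1ccc(OC)cc1` gives 57700 nM, and the step of a 1.2-fold lower number from compound 1 to compound 3 (0.10 log units; within the scatter) changes little. Compound 2 `COc1cc(-c2nnc(S)n2-c2ccc(N(C)C)cc2)cc(OC)c1OC` reaches only a limit of this assay, > 60000 nM. Going by the values given here, the step of an at least 1.2-fold lower number from compound 2 to compound 3 (0.11 log units; that floor lies within the scatter) is the one measured change on the sulfur. Compound 4 `COc1cc(-c2nnc(SCC(=O)c3ccc4ccccc4c3)n2-c2ccc(N(C)C)cc2)cc(OC)c1OC` carries (naphthalen-2-yl)carbonyl in place of methyl on a saturated chain carbon bound to a sulfur. The small step from a hydrogen to an ethyl on that sulfur gives no direct guide for so large an entering group, so the expectation rests on weak ground. A moderate fall in the number is expected, a 3.1-fold lower number from compound 3 to compound 4 (0.49 log units; beyond the scatter). Compound 4 is therefore estimated at 15000 nM, with a range from 3000 nM to 60000 nM.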

Compound 4, half-maximal inhibitory concentration: 18100 nM
Compound 4: the middle estimate sits 1.2-fold (0.08 log units) below what was measured, and the stated range covers the measured number.
By their numbers in this assay, from the lowest: compound 4; then compounds 3 and 1 (each within the scatter of the next). At a limit, above all of these: compound 2.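

In this assay, going by these compounds alone, the earlier steps have sizes or floors within the scatter, whereas a 2.6-fold lower number from compound 3 to compound 4 (0.41 log units; beyond the scatter) lies beyond it. This shows that the number at this saturated chain carbon bound to a sulfur can respond to a change, here (naphthalen-2-yl)carbonyl in place of methyl. Compound 2, with hydrogen on the sulfur, stays at a limit, so its distance from compound 4 cannot be sized: the limit of > 60000 nM in this assay, at which 1 of the 4 values shown sits.

The step cannot separate the carbonyl from the naphthalene rings. On these data alone, whether a benzoyl group, a longer alkyl chain or an amine on that chain would do the same remains open.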